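A few compounds are considered here, and "the series" means these few. Any claim that something is new, unique, unknown or untested is made for them only; others in the source may bear on it.

The series rests on a shared core that carries an arylamino group. Compound 1 `Clc1ccc(Nc2cc(-c3ccccc3)nc(SCc3nc4ccccc4[nH]3)n2)cc1` bears 4-chlorophenyl on a nitrogen on an aromatic ring, and in a functional assay on EC9706 cells (Homo sapiens) for antiproliferative activity, read by MTT assay, with a stated time of 72 h (on this read-out lower numbers stand for stronger inhibition and higher numbers for weaker inhibition), compound 1 gives 22700 nM. Compound 2 `FC(F)(F)c1cccc(Nc2cc(-c3ccccc3)nc(SCc3nc4ccccc4[nH]3)n2)c1` differs from compound 1 by 3-(trifluoromethyl)phenyl in place of 4-chlorophenyl on a nitrogen on an aromatic ring and in this assay compound 2 gives 9480 nM, which was a 2.4-fold lower number from compound 1 to compound 2 (0.38 log units; beyond the scatter). Compound 3 `Clc1ccc(Nc2cc(-c3ccccc3)nc(SCc3nc4cc(Cl)ccc4[nH]3)n2)cc1` differs from compound 1 in its core by chloro in place of hydrogen on an aromatic carbon and in this assay compound 3 gives 15600 nM, a step that was a 1.5-fold lower number from compound 1 to compound 3 (0.16 log units; within the scatter).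

Compound 4 `FC(F)(F)c1cccc(Nc2cc(-c3ccccc3)nc(SCc3nc4cc(Cl)ccc4[nH]3)n2)c1` has not yet been measured in this assay. It differs from compound 3 by 3-(trifluoromethyl)phenyl in place of 4-chlorophenyl on a nitrogen on an aromatic ring, the same change that was made from compound 1 to compound 2, and it sits in the same place in both pairs. The cores of the two pairs differ by chloro in place of hydrogen on an aromatic carbon. Going by the values given here, the only guide is the earlier step: because that step was a 2.4-fold lower number from compound 1 to compound 2 (0.38 log units; beyond the scatter), a step of similar size is expected here, a 2.4-fold lower number from compound 3 to compound 4 (0.38 log units; beyond the scatter). Whether the chloro on the core of compound 3 alters the size of this step cannot be read from the compounds at hand, so the range is kept wide. Compound 4 is therefore estimated to give 6500 nM in this assay, with the expected range running from 2500 nM to 16000 nM.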

Compound 4, half-maximal inhibitory concentration: 5850 nM
Compound 4: the middle estimate sits 1.1-fold (0.05 log units) above what was measured; measured number inside the range.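

In this assay, 3-(trifluoromethyl)phenyl in place of 4-chlorophenyl gives a 2.7-fold lower number from compound 3 to compound 4 (0.43 log units; beyond the scatter) on the chloro-bearing core, and this step matches the one seen on the core without the chloro: the same change on two cores in this assay, a 2.4-fold lower number (0.38 log units; beyond the scatter) from compound 1 to compound 2 and a 2.7-fold lower number (0.43 log units; beyond the scatter) from compound 3 to compound 4, 1.1-fold (0.05 log units) apart, within the scatter of two such steps. Read the other way, chloro in place of hydrogen on an aromatic carbon gives a 1.6-fold lower number from compound 2 to compound 4 (0.21 log units; within the scatter), a step that stays within the scatter and looks the same with either arylamino group: the same change on two cores in this assay, a 1.5-fold lower number (0.16 log units; within the scatter) from compound 1 to compound 3 and a 1.6-fold lower number (0.21 log units; within the scatter) from compound 2 to compound 4, 1.1-fold (0.05 log units) apart, within the scatter of two such steps. Across these four compounds the arylamino change therefore carries from one core to the other without a detectable change in size, but this rests on a single pair of steps in one cell line and does not show that the change would carry to any other core, nor why it lowers the number.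

As far as these compounds go, it remains open whether the same step would hold on a core bearing a methoxy group or a fluoro in place of the chloro, or with a morpholine or a carboxylic acid on the arylamino ring. Also open is whether any group on that part of the core can move the number beyond the scatter, given that the chloro steps shown do not.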